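The source may report more compounds than this note shows. Statements on the series, on what has been measured and on what is new or still open speak of the compounds shown alone.

Measured compounds in the series:
compound 1, `Cc1ccc(OCC(=O)N(Cc2cccs2)c2ccn(C)n2)cc1`: 855 nM
compound 2, `Cc1ccc(OCC(=O)N(Cc2cccs2)c2ncco2)cc1`: 0.3 nM
compound 3, `Cc1ccc(OCC(=O)N(C)Cc2cccs2)cc1`: 400 nM

In an assay on HEK293 cells for agonist activity at transient receptor potential cation channel subfamily M member 8 (Homo sapiens), read by fluorescence and calcium flux, with a stated time of 15 min (a lower number here means that less compound is needed, a higher number that more compound is needed for the effect), compound 3 gives 400 nM, the second highest of the three numbers. Its nearest neighbour is compound 1, reached by a modest step, a 2.1-fold lower number from compound 1 to compound 3 (0.33 log units; beyond the scatter). The furthest number is that of compound 2, separated by a large step, a 1300-fold higher number from compound 2 to compound 3 (3.12 log units; beyond the scatter).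

The next compound, compound 4, `Cc1ccc(OCC(=O)N(Cc2cccs2)c2nccn2C)cc1`, has not yet been measured. It differs from compound 3 in one place: 1-methyl-1H-imidazol-2-yl in place of methyl on an amide-type nitrogen. The measured steps that bear on this change are those in which the methyl of compound 3 stands in for a five-membered aromatic ring on the same nitrogen. With 1,3-oxazol-2-yl the number moves by a large amount, a 1300-fold higher number from compound 2 to compound 3 (3.12 log units; beyond the scatter), while with 1-methyl-1H-pyrazol-3-yl it moves only modestly and the other way, a 2.1-fold lower number from compound 1 to compound 3 (0.33 log units; beyond the scatter). The two rings thus pull in opposite directions, and the entering 1-methyl-1H-imidazol-2-yl is a third ring of the same size. A lower number in this assay is expected for compound 4, plausibly a large step, an 80-fold lower number from compound 3 to compound 4 (1.90 log units; beyond the scatter), though with wide uncertainty given the split between compound 1 and compound 2. The estimate for compound 4 is 5 nM, in the range 0.5 nM to 100 nM.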

Compound 4, half-maximal effective concentration: 1790 nM
For compound 4 the middle estimate is 360-fold (2.55 log units) below the measured one; measured number above the stated range.
By their numbers in this assay, from the lowest: compound 2; then compound 3; then compound 1; then compound 4.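

In this assay, a five-membered aromatic ring on the amide-type nitrogen does not by itself give a lower number than methyl: 1-methyl-1H-imidazol-2-yl moves the number modestly upward (a 4.5-fold higher number from compound 3 to compound 4 (0.65 log units; beyond the scatter)), the same direction as the 1-methyl-1H-pyrazol-3-yl of compound 1. The very low number of compound 2 therefore does not extend to every ring of this size, and not even to the other ring here attached through its 2-position, as the large step to the imidazole shows (a 6000-fold higher number from compound 2 to compound 4 (3.78 log units; beyond the scatter)). Compound 4 instead falls on the same side as compound 1, with a modest step separating them (a 2.1-fold higher number from compound 1 to compound 4 (0.32 log units; beyond the scatter)), so among the three rings only the 1,3-oxazol-2-yl of compound 2 gives a number below that of methyl compound 3. Nothing available explains why these rings differ.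

The compounds shown leave open whether the low number is particular to 1,3-oxazol-2-yl or is shared by a close relative such as 1,3-thiazol-2-yl. They also leave open how 1H-imidazol-2-yl without its methyl, or a phenyl ring, would stand on this nitrogen.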